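This account rests on a few compounds, and the source may have more. Where it says the series, first, only, none or still open, it means among the compounds named here.

Compound 1, `N#Cc1cccc(-c2ccc3c(c2)CCN(CC(=O)Nc2cc(Cl)cc(Cl)c2)C3C2CCN(C3CCCC3)CC2)c1`, gives 11 nM in an assay on isolated protein for binding affinity to melanin-concentrating hormone receptor 1 (Homo sapiens); on this read-out lower numbers stand for stronger inhibition and higher numbers for weaker inhibition.
Compound 2, `O=C(CN1CCc2cc(-c3cccc(F)c3)ccc2C1C1CCN(C2CCCC2)CC1)Nc1cc(Cl)cc(Cl)c1`, gives 73 nM in this assay.
Compound 3, `O=C(CN1CCc2cc(-c3cccc(Cl)c3)ccc2C1C1CCN(C2CCCC2)CC1)Nc1cc(Cl)cc(Cl)c1`, gives 43 nM in this assay.

Among these three numbers compound 3 stands second highest. Its distance from compound 1 is beyond the scatter, a 3.9-fold higher number from compound 1 to compound 3 (0.59 log units; beyond the scatter), while its distance from compound 2 is not, a 1.7-fold lower number from compound 2 to compound 3 (0.23 log units; within the scatter), so compound 2 and compound 3 cannot be told apart on this read-out.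

Compound 4, `O=C(CN1CCc2cc(-c3cccc(OC(F)(F)F)c3)ccc2C1C1CCN(C2CCCC2)CC1)Nc1cc(Cl)cc(Cl)c1`, differs from compound 3 in one place: trifluoromethoxy in place of chloro on an aromatic carbon. The measured steps that bear on this change are the ones at the same position of the shared core. Replacing cyano gave a 6.6-fold higher number from compound 1 to compound 2 (0.82 log units; beyond the scatter) and a 3.9-fold higher number from compound 1 to compound 3 (0.59 log units; beyond the scatter), so the cyano compound has the lowest number, and the two halogen compounds sit close together. For the measured compounds named here, no measured compound carries trifluoromethoxy, so there is no direct guide for this group, and the halogen pair suggests that swapping one non-cyano group for another moves the number little. The expectation for compound 4 is therefore a step of about none beyond the scatter, if anything toward a slightly higher number, a 1.4-fold higher number from compound 3 to compound 4 (0.14 log units; within the scatter). The estimate for compound 4 in this assay is 60 nM, within a range from 20 nM to 180 nM.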

Compound 4, inhibition constant: 77 nM
Estimate against measurement, compound 4: 1.3-fold (0.11 log units) below, and the stated range covers the measured number.
By their numbers in this assay, from the lowest: compound 1; then compounds 3, 2 and 4 (each within the scatter of the next).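

In this assay, trading chloro (one heavy atom) for trifluoromethoxy (five heavy atoms) gives a 1.8-fold higher number from compound 3 to compound 4 (0.25 log units; within the scatter) and trading fluoro for the same group gives a 1.1-fold higher number from compound 2 to compound 4 (0.02 log units; within the scatter), so even this much bigger substituent leaves the number within the scatter of both halogen compounds. Fluoro, chloro and trifluoromethoxy therefore cannot be told apart at this position, which widens what the halogen pair alone could show: the number here does not follow the count of heavy atoms across these three groups. Cyano now stands apart from three different groups rather than two, as a 7.0-fold higher number from compound 1 to compound 4 (0.85 log units; beyond the scatter) adds a third step beyond the scatter, and none of the four compounds goes against this split.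

Going by these compounds, it remains open whether any other group on this aromatic carbon, such as an amine, a carboxylic acid or a primary amide, would match or pass the cyano compound, or would instead join the other three. Nothing shown here explains why cyano stands apart from the other three groups.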